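The source may report more compounds than this note shows. Statements on the series, on what has been measured and on what is new or still open speak of the compounds shown alone.

In a functional assay on HepG2 cells (Homo sapiens) for antiproliferative activity, read by MTT assay, with a stated time of 48 h (on this read-out lower numbers stand for stronger inhibition and higher numbers for weaker inhibition), compound 1 (`COc1ccc(N(C)c2ccnc(Cl)n2)cc1`) gives 2120 nM. That places it level with compound 3 (`COc1ccc(N(C)c2ccnc(Cl)n2)cc1Cl`), which gives 2630 nM, while compound 2 (`COc1ccc(N(C)c2ccnc(Cl)n2)cc1F`) gives 844 nM, the lowest number of the three.

The open question is what happens in compound 4 (`COc1ccc(N(C)c2ccnc(Cl)n2)cc1O`), which differs from compound 1 as follows: hydroxy in place of hydrogen on an aromatic carbon. Two measured changes bear on this one, as each replaces hydrogen on that same aromatic carbon. Fluoro there gave a 2.5-fold lower number from compound 1 to compound 2 (0.40 log units; beyond the scatter), and chloro gave a 1.2-fold higher number from compound 1 to compound 3 (0.09 log units; within the scatter). Exchanging one halogen for the other gave a 3.1-fold higher number from compound 2 to compound 3 (0.49 log units; beyond the scatter). Across these three compounds, then, changes at this carbon have been modest at most, and only fluoro moved the number beyond the scatter relative to hydrogen. Hydroxy is neither of these groups, and no measured compound carries it, so these steps suggest only a likely size and not a firm direction. A small shift toward a lower number, or none beyond the scatter, is the most reasonable expectation. The expected outcome is a 1.5-fold lower number from compound 1 to compound 4 (0.18 log units; within the scatter). For compound 4 the estimated value is 1400 nM, with an expected range from 450 nM to 4300 nM.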

Compound 4, half-maximal inhibitory concentration: 464 nM
The estimate for compound 4 lay 3.0-fold (0.48 log units) above the measured number; the measured number falls inside the stated range.
By their numbers in this assay, from the lowest: compounds 4 and 2 (each within the scatter of the next); then compounds 1 and 3 (each within the scatter of the next).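

In this assay, a 4.6-fold lower number from compound 1 to compound 4 (0.66 log units; beyond the scatter) shows that hydroxy joins fluoro as a second group on this aromatic carbon, ortho to the methoxy group, that moves the number beyond the scatter relative to hydrogen, and in the same direction, while chloro in compound 3 goes against this pattern by staying level with hydrogen. The choice of group at this carbon matters in a clear way, as swapping chloro for hydroxy gives a 5.7-fold lower number from compound 3 to compound 4 (0.75 log units; beyond the scatter) in a single change, whereas swapping fluoro for hydroxy gives a 1.8-fold lower number from compound 2 to compound 4 (0.26 log units; within the scatter) and so leaves these two compounds indistinguishable in this test. Nothing shown here gives a measured reason for why hydroxy and fluoro behave alike and chloro does not.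

Going by these compounds, it remains open whether an amine, a carboxylic acid or a longer chain such as ethoxy on this same carbon would fall with hydroxy and fluoro or with chloro. Also unsettled is whether hydroxy would give a similar step on a core that differs from that of compound 1, since all four compounds share one core.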